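Amino in place of nitro on an aromatic carbon

The source may hold more compounds than are shown below. What is called first, only, known or untested is meant among the compounds shown, and "the series" means these compounds.

In a functional assay on HepG2 cells (Homo sapiens) for antiproliferative activity, read by MTT assay, with a stated time of 72 h (a lower number here means a stronger inhibitor of growth, a higher number a weaker inhibitor of growth), compound 1 `CC(C)Cn1c(SCc2ccccc2)nc(N)cc1=O` gives 77000 nM as its measured value. In this assay compound 2 `Cc1ccc2nc(-c3ccc([N+](=O)[O-])cc3)cn2c1` stands at > 100000 nM and this is a limit of the assay, not a number. Where compound 2 truly lies is therefore not known, and it offers no exact point from which to count.

Compound 3 `Cc1ccc2nc(-c3ccc(N)cc3)cn2c1` differs from compound 2 in one place, on an aromatic carbon of a six-membered aromatic ring of carbon only, para to a large group, where amino stands in place of nitro (amino in place of nitro on an aromatic carbon). The two compounds share the rest of their structure.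

Going by the values given here, no pair of measured compounds shows what such an exchange does. The only anchor is the limit of compound 2 (> 100000 nM). A small step toward stronger growth inhibition is expected, and it may stay within the scatter. In this assay the estimated change is an at least 1.4-fold lower number from compound 2 to compound 3 (0.15 log units; that floor lies within the scatter) and it remains a cautious expectation. For compound 3 the expected value is 70000 nM with an estimated range from 20000 nM to 150000 nM in this measurement.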

Compound 3, concentration for 50% growth inhibition: > 100000 nM
Compound 3: only a limit was reported; the forecaster's own chance of this, stated with the estimate: 45%; at least 1.4-fold (0.15 log units) between middle value and limit.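

No step can be read between compound 2 and compound 3, because each stands only at a limit of this assay and not at a number: the limit of > 100000 nM in this assay, at which 2 of the 3 values shown sit.

The compounds shown leave open where compound 2 and compound 3 truly lie, and whether amino in place of nitro on an aromatic carbon changes growth inhibition in either direction.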